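Swapping chloro for fluoro on a benzylsulfanyl arm

The source may report more compounds than this note shows. Statements on the series, on what has been measured and on what is new or still open speak of the compounds shown alone.

Measured compounds:
Compound 1, `COc1ccc(C2N=C(SCc3ccc(Cl)cc3)NC(C)=C2C(=O)Nc2ccc(F)cc2)cc1OC`, gives 22.2% in a functional assay on the whole organism (artery, strain albino) with Rattus norvegicus as the target, with a stated time of 720 min, at a dose of 10 mg/kg by the oral route; a lower number here means less inhibition, a higher number more inhibition at the dose given (going by the name of the read-out).
Compound 2, `COc1ccc(C2N=C(SCc3ccc(F)cc3)NC(C)=C2C(=O)Nc2ccc(F)cc2)cc1OC`, gives 17% in this assay.
Compound 3, `CC1=C(C(=O)Nc2ccc(Br)cc2)C(c2ccc(Cl)cc2Cl)N=C(SCc2ccc(Cl)cc2)N1`, gives 25.8% in this assay.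

Compound 1 and compound 2 share one core and differ only by fluoro in place of chloro on an aromatic carbon. That change made a step of a number 5.2 percentage points lower from compound 1 to compound 2 (within the scatter). Compound 3 has a different core; how its core differs from that of compound 1 is not broken down here. Compound 4, `CC1=C(C(=O)Nc2ccc(Br)cc2)C(c2ccc(Cl)cc2Cl)N=C(SCc2ccc(F)cc2)N1`, has not yet been measured; it differs from compound 3 by fluoro in place of chloro on an aromatic carbon, the same change as between compound 1 and compound 2. The expectation therefore rests on the step from compound 1 to compound 2: a step of about a number 5.2 percentage points lower from compound 3 to compound 4 (within the scatter) is expected for compound 4. Compound 4 is thus estimated at 20.6%, likely between 8% and 33%.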

Compound 4, a percentage reported as inhibition, in the whole organism at one dose (the size of the read-out at that dose, not a potency): 27.3%
Beside the measured number, compound 4's estimate is 6.7 percentage points below it; the range from low to high includes it.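

Carried onto the core of compound 3, the swap from (4-chlorobenzyl)sulfanyl to (4-fluorobenzyl)sulfanyl made a step of a number 1.5 percentage points higher from compound 3 to compound 4 (within the scatter) in this assay. Set beside the earlier step, the two cores do not separate: the same change on two cores in this assay, a number 5.2 percentage points lower (within the scatter) from compound 1 to compound 2 and a number 1.5 percentage points higher (within the scatter) from compound 3 to compound 4, 6.7 percentage points apart, within the scatter of two such steps. This gives no sign that the core alters what the change does, but it does not show that the change has no effect or that its size carries over exactly, and two pairs with such small steps could miss a modest difference.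

The compounds shown carry only chloro or fluoro on this benzyl ring, so the outcome with a methoxy group, a nitrile or a longer chain there stays open. Each reading also comes from a single dose, which leaves potency unknown.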